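The source may hold more compounds than are shown below. What is called first, only, known or untested is meant among the compounds shown, and "the series" means these compounds.

Compound 1 `Cc1nc(-c2cccnc2)sc1-c1nnc(-c2ccccc2Cl)o1` was tested in an ADME assay on HCT-116 cells (Homo sapiens) for cytotoxicity, read by MTT assay; on this read-out higher numbers stand for lower toxicity in this test and lower numbers for higher toxicity in this test. In this assay compound 1 gives > 100 ug/mL, which is a limit of the assay and not a number. Compound 2 `Cc1nc(-c2cccnc2)sc1-c1nnc(-c2ccc(Cl)cc2)o1` in this assay gives > 100 ug/mL, again a limit of the assay. Compound 3 `Cc1nc(-c2cccnc2)sc1-c1nnc(-c2ccc(O)cc2)o1` in this assay gives > 100 ug/mL, also a limit. Compound 1 therefore stands where every measured compound stands, at the limit of > 100 ug/mL in this assay, at which 3 of the 3 values shown sit. The step from compound 1 to compound 2 in this assay is a step that the two limits leave unreadable from compound 1 to compound 2, the step from compound 1 to compound 3 is a step that the two limits leave unreadable from compound 1 to compound 3, and the step from compound 2 to compound 3 is a step that the two limits leave unreadable from compound 2 to compound 3.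

Compound 4 `Cc1nc(-c2cccnc2)sc1-c1nnc(-c2ccccc2[N+](=O)[O-])o1` is the next compound. Its change from compound 1 is nitro in place of chloro on an aromatic carbon. The three measured steps all concern the same phenyl ring and none of them has a readable size, because in every case both ends sit at the limit of > 100 ug/mL in this assay, at which 3 of the 3 values shown sit. Going by the values given here, no measured step therefore points to a direction or size of change in this assay beyond the scatter. Compound 4 is estimated to sit at 150 ug/mL, between 50 ug/mL and 450 ug/mL. That estimate means a step from compound 1 of a step that the limit leaves unreadable from compound 1 to compound 4, most likely again only a limit.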

Compound 4, half-maximal cytotoxic concentration: > 100 ug/mL
Compound 4 ended at the assay's limit; the forecaster's own chance of this, stated with the estimate: 75%; the middle value lies beyond the limit too.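

Compound 4 gives > 100 ug/mL in this assay, which is a limit of the assay and not a number. The step from compound 1 to compound 4 therefore cannot be read, as both ends are limits: the limit of > 100 ug/mL in this assay, at which 4 of the 4 values shown sit.

The compounds shown leave open how far each lies past that limit, and whether swapping chloro, hydroxy or nitro changes the result in this assay at all.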